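The source may report more compounds than this note shows. Statements on the series, on what has been measured and on what is new or still open speak of the compounds shown alone.

Three compounds have been measured in an assay on HEK293 cells for agonist activity at Toll-like receptor 8 (Homo sapiens), read by spectrophotometry; on this read-out lower numbers stand for an effect already at smaller amounts and higher numbers for an effect only at larger amounts of compound:

compound 1, `CCCCNc1nc(N)nc(C)c1CC`, gives 1660 nM
compound 2, `CCCCNc1nc(N)nc(C)c1CCc1ccccc1`, gives 1190 nM
compound 3, `CCCCNc1nc(N)nc(C)c1CCCN(C)C`, gives 126 nM

Compound 3 gives the lowest of the three numbers; compound 2 sits nearest to it, compound 1 furthest, and both gaps lie beyond the scatter. Compound 4, `CCCCCc1c(C)nc(N)nc1NCCCC`, has not been measured yet. It differs from compound 3 by ethyl in place of dimethylamino on a saturated chain carbon, three bonds along the chain from an aromatic carbon, so the chain loses its dimethylamino group and ends as a plain pentyl. The measured steps that bear on this are those that brought the dimethylamino group in: a 13-fold lower number from compound 1 to compound 3 (1.12 log units; beyond the scatter) and a 9.4-fold lower number from compound 2 to compound 3 (0.98 log units; beyond the scatter), while the step without it, a 1.4-fold lower number from compound 1 to compound 2 (0.14 log units; within the scatter), stayed within the scatter. Taking the group away again is therefore expected to undo most of that gain, with compound 4 landing close to compounds 1 and 2. For compound 4 the expected step is a 10-fold higher number from compound 3 to compound 4 (1.01 log units; beyond the scatter), upward. Compound 4 is thus estimated at 1300 nM, within a range from 450 nM to 3800 nM.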

Compound 4, half-maximal effective concentration: 1220 nM
Estimate against measurement, compound 4: 1.1-fold (0.03 log units) above, and the stated range covers the measured number.
By their numbers in this assay, from the lowest: compound 3; then compounds 2, 4 and 1 (each within the scatter of the next).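

In this assay, ethyl in place of dimethylamino at the end of the chain gives a 9.7-fold higher number from compound 3 to compound 4 (0.99 log units; beyond the scatter) and leaves a plain pentyl, so a chain of this kind does not reach the low number without its dimethylamino group. The plain pentyl chain shows a 1.0-fold higher number from compound 2 to compound 4 (0.01 log units; within the scatter) and also a 1.4-fold lower number from compound 1 to compound 4 (0.13 log units; within the scatter) in a comparison with the shorter ethyl chain, so among these compounds, only the dimethylamino group moves the number beyond the scatter. No accompanying measurement explains this difference.

From the compounds shown here alone, it remains open whether a primary amine, a pyrrolidine or a morpholine at the chain end would give a similarly low number, or whether an uncharged oxygen group such as a methyl ether would. A shorter or longer chain carrying the same dimethylamino group also remains to be compared.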